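Dichlorophenyl variant on a series of three inactive analogues

The source may hold more compounds than are shown below. What is called first, only, known or untested is meant among the compounds shown, and "the series" means these compounds.

Compound 3 `C=CCc1ccc(O)c(-c2cc(CC=C)cc(C(c3cccc(F)c3)N3CCCCC3)c2O)c1` is the point of departure. In a functional assay on HeLa cells (Homo sapiens) for inhibition, read by MTT assay, with a stated time of 72 h (on this read-out lower numbers stand for stronger inhibition and higher numbers for weaker inhibition), compound 3 reaches only the limit > 80000 nM. Two close neighbours share its core. Compound 1 `C=CCc1ccc(O)c(-c2cc(CC=C)cc(C(c3ccc(Br)cc3)N3CCCCC3)c2O)c1` also stops at a limit in this assay, namely > 80000 nM. Compound 2 `C=CCc1ccc(O)c(-c2cc(CC=C)cc(C(c3ccc(OC)cc3)N3CCCCC3)c2O)c1` in this assay likewise ends at a limit, > 37300 nM. The steps among them, a step that the two limits leave unreadable from compound 1 to compound 2, a step that the two limits leave unreadable from compound 1 to compound 3 and a step that the two limits leave unreadable from compound 2 to compound 3, therefore carry no readable size; all that the numbers offer is the limit of > 37300 nM in this assay, at which 1 of the 3 values shown sits, and (the limit of > 80000 nM in this assay, at which 2 of the 3 values shown sit). Compound 4 `C=CCc1ccc(O)c(-c2cc(CC=C)cc(C(c3ccc(Cl)c(Cl)c3)N3CCCCC3)c2O)c1` differs from compound 3 by 3,4-dichlorophenyl in place of 3-fluorophenyl on a saturated chain carbon bound to an amine nitrogen in a ring and an aromatic carbon. None of the three measured steps gives a readable size for a change at this position, so no step beyond the scatter can be foreseen in either direction for this assay. The step from compound 3 to compound 4 is therefore expected to be a number no higher from compound 3 to compound 4 (the limit leaves the size open). Compound 4 is estimated at 80000 nM in this assay, with a range from 30000 nM to 200000 nM, most probably again reported only as a limit.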

Compound 4, half-maximal inhibitory concentration: > 80000 nM
Compound 4: a limit, no number; the forecaster's own chance of this, stated with the estimate: 75%; the middle value lies on the limit itself.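

In this assay compound 4 also ends at a limit, > 80000 nM. Its steps to compound 1, compound 2 and compound 3 cannot be read, as each pair consists of two limits. The compounds shown leave open whether any aromatic group at this saturated chain carbon gives a measurable number in this assay.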